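Benzimidazole chalcone series: sulfonamide variant, methyl for chloro

The source may hold more compounds than are shown below. What is called first, only, known or untested is meant among the compounds shown, and "the series" means these compounds.

Measured so far in a functional assay on HCT-116 cells (Homo sapiens) for antiproliferative activity, read by MTT assay, with a stated time of 48 h; on this read-out lower numbers stand for stronger inhibition and higher numbers for weaker inhibition:
compound 1 `COc1cccc(C(=O)Nc2cccc(/C=C/C(=O)c3nc4ccccc4[nH]3)c2)c1` gives 3680 nM;
compound 2 `Cc1cc(C)cc(C(=O)Nc2cccc(/C=C/C(=O)c3nc4ccccc4[nH]3)c2)c1` gives 1550 nM;
compound 3 `O=C(/C=C/c1cccc(NS(=O)(=O)c2ccccc2Cl)c1)c1nc2ccccc2[nH]1` gives 987 nM.

Compound 3 carries the lowest number of the three. One of its steps is beyond the scatter (a 3.7-fold lower number from compound 1 to compound 3 (0.57 log units; beyond the scatter)), but the other is not (a 1.6-fold lower number from compound 2 to compound 3 (0.20 log units; within the scatter)), so compound 3 cannot be called the most potent on these numbers. Among the amides, a 2.4-fold lower number from compound 1 to compound 2 (0.38 log units; beyond the scatter).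

Compound 4 `Cc1ccccc1S(=O)(=O)Nc1cccc(/C=C/C(=O)c2nc3ccccc3[nH]2)c1` is the next step from compound 3: methyl in place of chloro on an aromatic carbon. Within the data shown here, none of the measured steps touches this part of the molecule: all three concern the group on the ring nitrogen as a whole, not a substituent on the outer ring. The change keeps the sulfonyl linker, the ring and the substituent count; only the identity of the group ortho to a large group is swapped. Among the measured compounds shown here, with no bearing step in the set, and an exchange of one heavy atom for another of the same size class, the expected step is none beyond the scatter, in either direction.

Compound 4 is therefore estimated at 1000 nM in this assay, with a range from 400 nM to 2500 nM; the step of a 1.0-fold higher number from compound 3 to compound 4 (0.01 log units; within the scatter) is expected to fall within the scatter.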

Compound 4, half-maximal inhibitory concentration: 955 nM
The estimate for compound 4 lay 1.0-fold (0.02 log units) above the measured number; measured number inside the range.
By their numbers in this assay, from the lowest: compounds 4, 3 and 2 (each within the scatter of the next); then compound 1.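

In this assay, among these compounds, this is the first reading of a substituent on the outer ring rather than of the whole group on the ring nitrogen, and at this place, ortho to a large group, methyl and chloro are not told apart (a 1.0-fold lower number from compound 3 to compound 4 (0.01 log units; within the scatter)). With methyl in place of chloro, the sulfonamide stands as compound 3 did against both amides: within the scatter of the 3,5-dimethylphenyl amide (a 1.6-fold lower number from compound 2 to compound 4 (0.21 log units; within the scatter)) and beyond it against the 3-methoxyphenyl amide (a 3.9-fold lower number from compound 1 to compound 4 (0.59 log units; beyond the scatter)). No measurement at hand bears on why these two groups read alike.

As far as these compounds go, only chloro and methyl have been read at this place, so an amine, a carboxylic acid or a nitrile there remains open, as does the same exchange elsewhere on the ring. The compounds shown also contain no amide and sulfonamide with the same outer ring, so the contribution of the sulfonyl linker cannot be separated from that of the ring and its substituents.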